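The source may report more compounds than this note shows. Statements on the series, on what has been measured and on what is new or still open speak of the compounds shown alone.

Among the compounds with values here, an account of the series so far begins with three compounds measured in an ADME assay on a cell-free system (plasma, Rattus norvegicus) for metabolic stability, read by LC-MS, with a stated time of 60 min, at 37 degrees C, tested at 50 uM; on this read-out lower numbers stand for a less stable compound and higher numbers for a more stable compound. Compound 1 `CC(C)C(=O)OCOC(=O)C1=C(S[C@@H]2CN[C@H](C(=O)Nc3cccc(C(=O)O)c3)C2)[C@H](C)[C@@H]2[C@@H]([C@@H](C)O)C(=O)N12` gives 0% in this assay. Compound 2 `C[C@@H](O)[C@H]1C(=O)N2C(C(=O)OCOC(=O)C(C)(C)C)=C(S[C@@H]3CN[C@H](C(=O)Nc4cccc(C(=O)O)c4)C3)[C@H](C)[C@H]12` gives 0%, and compound 3 `C[C@@H](O)[C@H]1C(=O)N2C(C(=O)OCOC(=O)OC(C)(C)C)=C(S[C@@H]3CN[C@H](C(=O)Nc4cccc(C(=O)O)c4)C3)[C@H](C)[C@H]12` gives 0%. Compound 3 therefore stands level with compounds 1 and 2 at the digits shown: the step of no change at the digits printed from compound 1 to compound 3 (within the scatter) and the step of no change at the digits printed from compound 2 to compound 3 (within the scatter) both lie within the scatter, and so does the step of no change at the digits printed from compound 1 to compound 2 (within the scatter). All three measured steps concern exchanges of the group on a carbonyl carbon of the shared core, and none of them moves the read-out away from zero.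

The next compound, compound 4 `C[C@@H](O)[C@H]1C(=O)N2C(C(=O)OCOC(=O)OC(C)(C)C)=C(S[C@@H]3CN[C@H](C(=O)Nc4cccc(C(=O)OCOC(=O)OC(C)(C)C)c4)C3)[C@H](C)[C@H]12`, is not yet measured. It differs from compound 3 in one place: ((tert-butoxycarbonyl)oxy)methyl in place of hydrogen on an oxygen next to a carbonyl group. Within the data shown here, no measured step alters this part of the molecule, so the expectation rests only on the fact that compounds 1, 2 and 3 all sit at the floor of the read-out and that none of the changes among them shifted it. The step of no change at the digits printed from compound 3 to compound 4 (within the scatter) is therefore expected to lie within the scatter. Compound 4 is expected to give 0% in this assay, with a range from 0% to 10%.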

Compound 4, percent of the compound remaining: 8%
Estimate against measurement, compound 4: 8 percentage points below; measured number inside the range.
By their numbers in this assay, from the lowest: compounds 1, 2, 3 and 4 (each within the scatter of the next).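

In this assay, putting ((tert-butoxycarbonyl)oxy)methyl in place of hydrogen on an oxygen next to a carbonyl group gives a number 8 percentage points higher from compound 3 to compound 4 (within the scatter), the first step shown at this position. Compounds 1, 2 and 3 all keep this hydrogen and differ only in the group on a carbonyl carbon elsewhere in the molecule, so they could say nothing about this site; compound 4 shows that this large exchange here still leaves the read-out within the scatter of compound 3. Nothing available bears on what lies behind the value of compound 4.

With a single step at this oxygen, the compounds shown leave open whether a plain methyl, a longer chain or a chain ending in an amine on the same oxygen would read the same way in this assay. They also leave open whether ((tert-butoxycarbonyl)oxy)methyl at this position would give a comparable reading when paired with the isobutyryl or pivaloyl ester of compounds 1 and 2 at the other carbonyl.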